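A few compounds are considered here, and "the series" means these few. Any claim that something is new, unique, unknown or untested is made for them only; others in the source may bear on it.

Measured compounds:
- Compound 1, `CCC(COc1cccc(C(F)(F)F)c1)OC(=O)NCc1ccccc1`: in an assay for inhibition of zeta-carotene desaturase, chloroplastic/chromoplastic (Capsicum annuum), using a Dixon plot, with a stated time of 8 h (on this read-out higher numbers stand for weaker inhibition and lower numbers for stronger inhibition), compound 1 gives > 100000 nM, a limit of the assay rather than a number.
- Compound 2, `CCC(COc1cccc(Br)c1)OC(=O)NCc1ccccc1`: in this assay compound 2 gives > 100000 nM, again a limit of the assay rather than a number.

For the measured compounds named here, compound 2 therefore does not stand at any definite point on the scale: its value is only a limit, and the one other value shown is a limit as well, so no order between the two compounds can be read. Going by the values given here, the only measured step, a step that the two limits leave unreadable from compound 1 to compound 2, is left unreadable by the two limits. The whole picture so far is summed up in the limit of > 100000 nM in this assay, at which 2 of the 2 values shown sit.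

Compound 3, `CCC(COc1cccc(NC(C)=O)c1)OC(=O)NCc1ccccc1`, is not yet measured in this assay. It differs from compound 2 by one change: acetamido in place of bromo on an aromatic carbon. The measured step does bear on this change in that it swaps one group on the same aromatic carbon, but because of the limit of > 100000 nM in this assay, at which 2 of the 2 values shown sit, it gives no readable size, in either direction. No step beyond the scatter can be predicted.

Compound 3 is therefore expected to sit at or near the limit as well, with an estimated value of 200000 nM (range 50000 nM to 1000000 nM), which means an expected step that the limit leaves unreadable from compound 2 to compound 3.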

Compound 3, half-maximal inhibitory concentration: > 100000 nM
Compound 3: no number, only a limit; the forecaster's own chance of this, stated with the estimate: 85%; the middle value does not contradict the limit.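

No size can be read for the steps among compound 1, compound 2 and compound 3, because all three compounds give only a limit of the assay and not a number: the limit of > 100000 nM in this assay, at which 3 of the 3 values shown sit. The compounds shown leave open whether any other group on this aromatic carbon, or any change elsewhere in the shared core, would give a measurable value in this assay.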